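A few compounds are considered here, and "the series" means these few. Any claim that something is new, unique, unknown or untested is made for them only; others in the source may bear on it.

Values in a functional assay on the whole organism for inhibition, with Cavia porcellus as the target; on this read-out higher numbers stand for an effect only at larger amounts of compound and lower numbers for an effect already at smaller amounts:
Compound 1 `COc1ccccc1OCC1SCCN1C(=O)C[S+](C)[O-]`: 25 mg/kg
Compound 2 `COc1ccccc1OCC1SCCN1C(=O)CC(=O)O`: 20 mg/kg
Compound 3 `COc1ccccc1OCC1SCCN1C(=O)C(C)(C)C(=O)O`: 34 mg/kg

These three compounds share one core and differ only in what sits on the carbonyl carbon. With 20 mg/kg, compound 2 cannot be told apart from the other two, since a 1.3-fold lower number from compound 1 to compound 2 (0.10 log units; within the scatter) and a 1.7-fold higher number from compound 2 to compound 3 (0.23 log units; within the scatter) are both within the scatter. The numbers therefore set no order among the three.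

Compound 4 `COc1ccccc1OCC1SCCN1C(=O)CC(=O)NCc1ccccn1` keeps everything in compound 2 except one group: ((pyridin-2-yl)methyl)amino in place of hydroxy on a carbonyl carbon. Put simply, ((pyridin-2-yl)methyl)amino stands in place of hydroxy on a carbonyl carbon.

Among the measured compounds shown here, no measured pair makes this exact change, and no measured compound carries an aromatic ring at this place, so the evidence is indirect. The nearest guide is that changes in this part of the molecule have so far moved this assay very little: a 1.7-fold higher number from compound 2 to compound 3 (0.23 log units; within the scatter), and likewise a 1.4-fold higher number from compound 1 to compound 3 (0.13 log units; within the scatter), which is also within the scatter. The entering group is larger than any of those, so the uncertainty is wide, but the data give no reason to expect a direction.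

The expected result is a 1.3-fold higher number from compound 2 to compound 4 (0.10 log units; within the scatter), which means no expected change beyond the scatter. For compound 4 the estimated value is 25 mg/kg, with an expected range from 10 mg/kg to 60 mg/kg.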

Compound 4, dose for half-maximal effect: 26 mg/kg
Compound 4: middle estimate off by 1.0-fold (0.02 log units), on the low side; the measured number falls inside the stated range.
By their numbers in this assay, from the lowest: compounds 2, 1, 4 and 3 (each within the scatter of the next).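

In this assay, putting ((pyridin-2-yl)methyl)amino in place of hydroxy on this carbonyl carbon gives a 1.3-fold higher number from compound 2 to compound 4 (0.11 log units; within the scatter), a step within the scatter. The earlier compounds shown here carried only small groups without a ring at this place, so compound 4 adds something new: a group with a six-membered aromatic ring can stand here with no measurable change in the dose needed, and the hydroxy of compound 2 can be exchanged without a clear loss or gain. Nothing available explains why this large exchange leaves the read-out so flat.

Every step among these compounds lies within the scatter, so it remains open what kind of group at this place, if any, would move the dose clearly in either direction. Benzylamino, which has a ring with no hetero atom, a simple amino group, or a longer chain ending in the same pyridine ring could each help to show whether this flat picture holds for other groups.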